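Methyl for methoxy on the pendant ring of a chromone

The compounds below may be only part of what the source reports. "The series", "measured", "known", "first", "only" and "open" are said of these compounds alone.

Measured compounds:
compound 1 `COc1ccc(-c2cc(=O)c3ccc(OC)cc3o2)cc1` 49700 nM
compound 2 `Cc1ccc([C@H]2CC(=O)c3ccc(F)cc3O2)cc1` 150 nM
compound 3 `COc1ccc(-c2cc(=O)c3ccc(F)cc3o2)cc1` 1340 nM

In an in vitro assay on BTI-TN-5B1-4 cells for inhibition of Amine oxidase [flavin-containing] B (Homo sapiens) (a lower number here means a stronger inhibitor, a higher number a weaker inhibitor), compound 3 gives 1340 nM, the second highest of the three numbers; compound 2 gives 150 nM and compound 1 gives 49700 nM. Compound 4 `Cc1ccc(-c2cc(=O)c3ccc(F)cc3o2)cc1` differs from compound 3 by methyl in place of methoxy on an aromatic carbon. Among the compounds with values here, the one measured step, a 37-fold lower number from compound 1 to compound 3 (1.57 log units; beyond the scatter), concerns a different position, the core, and does not bear on this change. Compound 2 carries the same methyl but also a different core, so its value only hints that a methyl here is tolerated. Without a directly comparable step, compound 4 is expected at 400 nM, between 80 nM and 2000 nM, which means an estimated step of a 3.4-fold lower number from compound 3 to compound 4 (0.53 log units; beyond the scatter).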

Compound 4, half-maximal inhibitory concentration: 4330 nM
Estimate against measurement, compound 4: 11-fold (1.03 log units) below; the whole stated range lies below it.
By their numbers in this assay, from the lowest: compound 2; then compound 3; then compound 4; then compound 1.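

Methyl in place of methoxy, para to a large group, gives a 3.2-fold higher number from compound 3 to compound 4 (0.51 log units; beyond the scatter) in this assay, so with this core the methoxy compound is the stronger inhibitor of the pair. The methyl of compound 2 therefore offers no guide to this core, where the change costs potency. No measurement at hand explains this step.

On these data alone, it remains open how an amine, a chlorine atom or a longer chain such as ethoxy would fare at this position. As far as these compounds go, it is also open whether the same change would run the same way on the core of compound 2.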